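Urea-linked side chain on the shared core

This account rests on a few compounds, and the source may have more. Where it says the series, first, only, none or still open, it means among the compounds named here.

Among the measured compounds shown here, compound 2 `COc1ccc(-c2nc(/N=C(\N)NC(C)C)sc2-c2ccc(OC)cc2)cc1` gives 9.1 uM in a functional assay (aorta) with Rattus norvegicus as the target (on this read-out lower numbers stand for an effect already at smaller amounts and higher numbers for an effect only at larger amounts of compound), the highest of the three numbers so far. Compound 1 `COc1ccc(-c2nc(N=C(N)N)sc2-c2ccc(OC)cc2)cc1` gives 2 uM in this assay, and compound 3 `COc1ccc(-c2nc(CNC(=O)CSc3ccccc3)sc2-c2ccc(OC)cc2)cc1` gives 4.2 uM. For the measured compounds named here, the only single-change step measured is a 4.6-fold higher number from compound 1 to compound 2 (0.66 log units; beyond the scatter), so keeping the isopropyl, as compound 4 does, gives no reason to expect a fall back to the number of compound 1. Compound 4 `COc1ccc(-c2nc(CNC(=O)NC(C)C)sc2-c2ccc(OC)cc2)cc1` differs from compound 2 by a group of 8 heavy atoms (5 carbon, 2 nitrogen, 1 oxygen; no ring) in place of a group of 7 heavy atoms (4 carbon, 3 nitrogen; no ring), on an aromatic carbon. Going by the values given here, no measured step covers this exchange; compound 3, which also carries a chain joined through a carbonyl on the same aromatic carbon, stands lower than compound 2 by a margin beyond the scatter. The expected step is therefore a 1.8-fold lower number from compound 2 to compound 4 (0.26 log units; within the scatter), a modest fall. Compound 4 is expected to give 5 uM, within 1.5 uM to 15 uM.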

Compound 4, concentration for half-maximal effect: 5.7 uM
Compound 4: middle estimate off by 1.1-fold (0.06 log units), on the low side, within the range that was stated.
By their numbers in this assay, from the lowest: compound 1; then compounds 3, 4 and 2 (each within the scatter of the next, the first and the last beyond it).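

In this assay, the ((isopropylcarbamoyl)amino)methyl group on this aromatic carbon cannot be told apart from the group it replaces in compound 2 (a 1.6-fold lower number from compound 2 to compound 4 (0.20 log units; within the scatter)), nor from the (phenylsulfanyl)methyl end of the chain in compound 3 (a 1.4-fold higher number from compound 3 to compound 4 (0.13 log units; within the scatter)). The group of compound 1 remains separate from this chain (a 2.9-fold higher number from compound 1 to compound 4 (0.45 log units; beyond the scatter)). No available evidence explains these numbers.

From the compounds shown here alone, whether isopropylamino on the carbonyl carbon can give way to a plain amine or a longer chain without moving the number remains open. So does the effect of a carboxylic acid at the end of the chain.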